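Methyl to ethyl on the ring amide-type nitrogen chain

A few compounds are considered here, and "the series" means these few. Any claim that something is new, unique, unknown or untested is made for them only; others in the source may bear on it.

The series is read in a functional assay on A549 cells (Homo sapiens) for inhibition, read by MTT assay, with a stated time of 72 h; a lower number here means a stronger inhibitor, a higher number a weaker inhibitor. Compound 1 `CN1C(=O)N(c2ccccc2)C2NC(=S)N(/N=C/C=C/c3ccccc3)C21` gives in this assay only a limit of the assay, > 100000 nM. Compound 2 `COc1ccccc1/C=C/C=N/N1C(=S)NC2C1N(C)C(=O)N2c1ccccc1`, carrying a methoxy in place of hydrogen on an aromatic carbon, likewise gives in this assay only a limit, > 100000 nM. The step from compound 1 to compound 2 is a step that the two limits leave unreadable from compound 1 to compound 2; with both ends at limits it cannot be read, and the limit of > 100000 nM in this assay, at which 2 of the 2 values shown sit, is the whole of what the two values show. Compound 2 therefore stands at that limit and nowhere more exactly.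

Compound 3 `CCN1C(=O)N(c2ccccc2)C2NC(=S)N(/N=C/C=C/c3ccccc3OC)C21` differs from compound 2 by methyl in place of hydrogen on a saturated chain carbon bound to an amide-type nitrogen in a ring; cut one bond further out, the change reads methyl to ethyl. Among the compounds with values here, no measured step touches this place, and the single step in hand is unreadable, so nothing in the data argues for a change in this assay beyond the scatter. The expected step is a step that the limit leaves unreadable from compound 2 to compound 3, none beyond the scatter. Compound 3 is accordingly estimated at 150000 nM in this assay, within 40000 nM to 600000 nM, most probably reported once more only as a limit.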

Compound 3, half-maximal inhibitory concentration: > 100000 nM
Compound 3: only a limit was reported; the forecaster's own chance of this, stated with the estimate: 85%; the middle value does not contradict the limit.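

In this assay, within the data shown here, compound 3 gives > 100000 nM, again only a limit of the assay, and no step between compound 2 and compound 3 can be read. All three compounds share one reading: the limit of > 100000 nM in this assay, at which 3 of the 3 values shown sit. The compounds shown leave open whether any change on the shared core gives a measurable value in this assay.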